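Removing the amide arm from compound 1: stability expectation

A few compounds are considered here, and "the series" means these few. Any claim that something is new, unique, unknown or untested is made for them only; others in the source may bear on it.

Compound 1 `O=C(N[C@@H]1C[C@@H](C(=O)NC[C@@H]2CC(Br)=NO2)N(C(=O)OCc2cnc3ccccc3c2)C1)c1cccnc1` was tested in an ADME assay on the whole organism (strain CD-1) for metabolic stability, with Mus musculus as the target, at a dose of 50 mg/kg by the oral route (a lower number here means that the compound disappears faster, a higher number that the compound lasts longer), and gave 0.25 h. For the measured compounds named here, its close relative compound 2 `O=C(N[C@@H]1C[C@@H](C(=O)NC[C@@H]2CC(Br)=NO2)N(C(=O)OCc2cnc3ccccc3c2)C1)c1ccc(O)cc1` carries 4-hydroxyphenyl in place of pyridin-3-yl on a carbonyl carbon and in this assay compound 2 gives 0.25 h; the step of no change at the digits printed from compound 1 to compound 2 (within the scatter) shows no change within the scatter, so compound 1 stands level with compound 2 on the numbers measured so far.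

Compound 3 `O=C(NC[C@@H]1CC(Br)=NO1)[C@@H]1CCCN1C(=O)OCc1cnc2ccccc2c1` has not yet been measured in this assay. It differs from compound 1 in one place: hydrogen in place of ((pyridin-3-yl)carbonyl)amino on a saturated ring carbon. Going by the values given here, the only measured step, from compound 1 to compound 2, swaps one aromatic ring for another while keeping the whole amide arm, so it says little about taking that arm away entirely; no measured pair bears directly on this change.

With that thin basis, the estimate for compound 3 rests on the values of compound 1 and compound 2, and the expected step of a 1.2-fold higher number from compound 1 to compound 3 (0.08 log units; within the scatter) is none beyond the scatter, though with a wide margin of uncertainty. Compound 3 is therefore expected to show about 0.3 h, somewhere between 0.1 h and 0.8 h.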

Compound 3, half-life: 0.25 h
Beside the measured number, compound 3's estimate is 1.2-fold (0.08 log units) above it, and the stated range covers the measured number.
By their numbers in this assay, from the lowest: compounds 1, 2 and 3 (each within the scatter of the next).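

Until now only the aromatic ring at the far end of the amide arm had been varied, whereas here the whole arm is replaced by hydrogen, and in this assay this gives no change at the digits printed from compound 1 to compound 3 (within the scatter) and no change at the digits printed from compound 2 to compound 3 (within the scatter). On this saturated ring carbon, two ring bonds from the ring nitrogen, the half-life therefore reads the same with ((pyridin-3-yl)carbonyl)amino, with ((4-hydroxyphenyl)carbonyl)amino and with hydrogen, so among these three compounds the amide arm makes no measurable difference, even though nine heavy atoms and a whole aromatic ring leave with it. No measurement shown here accounts for this lack of difference, or says what sets the half-life in the mouse.

The compounds shown leave open whether any other group on this carbon would move the half-life beyond the scatter, for instance a plain amine, a carboxylic acid or a longer alkyl chain. They also leave open whether a change elsewhere on the core of compound 3 would do so, as every compound here shares the rest of that structure.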